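Naphthalen-1-yl for phenyl on the sulfonamide nitrogen

The source may hold more compounds than are shown below. What is called first, only, known or untested is meant among the compounds shown, and "the series" means these compounds.

Measured compounds:
compound 1, `CN(C)CCn1c(=O)sc2cc(S(=O)(=O)N(C)c3ccccc3)ccc21`: 5%
compound 2, `CN(C)CCn1c(=O)sc2cc(S(=O)(=O)N(C)c3cccc4ccccc34)ccc21`: 0%
compound 3, `O=c1sc2cc(S(=O)(=O)Nc3ccccc3)ccc2n1CCN1CCCC1`: 37%

In an assay on HEK293 cells for displacement of a labelled ligand from 5-hydroxytryptamine receptor 6 (Homo sapiens), read by radioligand binding, with a stated time of 60 min, tested at 100 nM (on this read-out higher numbers stand for more inhibition at the one concentration tested (going by the name of the read-out) and lower numbers for less inhibition), compound 1 gives 5% and compound 2 gives 0%. The change between them is naphthalen-1-yl in place of phenyl on a sulfonamide nitrogen and the step of a number 5 percentage points lower from compound 1 to compound 2 (within the scatter) lies within the scatter. Compound 3 gives 37%, the highest of the three numbers; its steps to compound 1 and to compound 2 both lie beyond the scatter. How the core of compound 3 differs from the core of compound 1 is not broken down here.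

Compound 4, `O=c1sc2cc(S(=O)(=O)Nc3cccc4ccccc34)ccc2n1CCN1CCCC1`, is not yet measured in this assay. It carries the change (naphthalen-1-yl in place of phenyl on a sulfonamide nitrogen). The place is not the same word for word: in compound 1 the sulfonamide nitrogen has a saturated chain carbon and the sulfonyl sulfur as other neighbours, in compound 3 only the sulfonyl sulfur, so this is the same kind of change rather than the same change.

Since the measured step of a number 5 percentage points lower from compound 1 to compound 2 (within the scatter) is within the scatter, the step from compound 3 to compound 4 is expected to be small, about a number 7 percentage points lower from compound 3 to compound 4 (within the scatter). Compound 4 is estimated at 30%, between 5% and 60%.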

Compound 4, a percentage reported as inhibition, at one concentration (the size of the read-out at that concentration, not a potency): 0%
Beside the measured number, compound 4's estimate is 30 percentage points above it, outside the stated range (below it).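

In this assay the change from phenyl to naphthalen-1-yl on the sulfonamide nitrogen does not carry over at one size, and on the second core it gives a large loss, a number 37 percentage points lower from compound 3 to compound 4 (beyond the scatter), so the step seen on one core does not predict the step on the other: the same change on two cores in this assay, a number 5 percentage points lower (within the scatter) from compound 1 to compound 2 and a number 37 percentage points lower (beyond the scatter) from compound 3 to compound 4, 32 percentage points apart, beyond the scatter of two such steps.
Compound 1 already stands at 5% and leaves little room for a fall, so its small step, a number 5 percentage points lower from compound 1 to compound 2 (within the scatter), cannot show that the number stays level with this change on that core.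
Which difference between the cores sets the two steps apart is not shown, and each number comes from a single concentration, so no potency can be read from it.

Open, on these data alone, is whether the loss on the core of compound 3 is specific to naphthalen-1-yl or also appears with other groups in place of phenyl, such as naphthalen-2-yl or benzyl. Also open, as far as these compounds go, is what a methyl group on the sulfonamide nitrogen does alone when the rest of compound 3 is kept.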